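Methyl for chloro on two cores, one small step known

A few compounds are considered here, and "the series" means these few. Any claim that something is new, unique, unknown or untested is made for them only; others in the source may bear on it.

Measured so far:
compound 1, `N=c1sc(=S)[nH]c2c1cc(-c1ccc(Cl)cc1)n2-c1ccccc1` — 2%
compound 2, `Cc1ccc(-c2cc3c(=N)sc(=S)[nH]c3n2-c2ccccc2)cc1` — 0%
compound 3, `CCC(C)Sc1nc2c(cc(-c3ccc(Cl)cc3)n2-c2ccccc2)c(=N)s1` — 2%

All three were tested in a functional assay on the whole organism for inhibition, with Rattus norvegicus as the target, read by ELISA, with stated times of 30 min and 6 h, at a dose of 30 mg/kg by the oral route; on this read-out higher numbers stand for more inhibition at the one dose given (going by the name of the read-out) and lower numbers for less inhibition. Compound 1 gives 2%, and compound 2, which carries the change (methyl in place of chloro on an aromatic carbon), gives 0%; the step between them is a number 2 percentage points lower from compound 1 to compound 2 (within the scatter). Compound 3 carries a different core; the difference between the two cores is not broken down here. In this assay compound 3 gives 2%, level with compound 1 and within the scatter of compound 2.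

Compound 4, `CCC(C)Sc1nc2c(cc(-c3ccc(C)cc3)n2-c2ccccc2)c(=N)s1`, has not yet been measured. It differs from compound 3 by methyl in place of chloro on an aromatic carbon, the same change that turns compound 1 into compound 2, at the same place on the same kind of ring. Because the earlier case gave a number 2 percentage points lower from compound 1 to compound 2 (within the scatter) and all three known values lie within the scatter of one another, only a small step is expected: a number 1 percentage points lower from compound 3 to compound 4 (within the scatter). Compound 4 is therefore expected to give about 1%, somewhere between -8% and 10%.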

Compound 4, a percentage reported as inhibition, in the whole organism at one dose (the size of the read-out at that dose, not a potency): 2%
Compound 4: middle estimate off by 1 percentage points, on the low side; the range from low to high includes it.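

In this assay, methyl in place of chloro on the aromatic carbon shows no change at the digits printed from compound 3 to compound 4 (within the scatter). Set beside the same change on the core of compound 1, this step shows that the change carries from one core to the other without a difference that stands clear of the scatter: the same change on two cores in this assay, a number 2 percentage points lower (within the scatter) from compound 1 to compound 2 and no change at the digits printed (within the scatter) from compound 3 to compound 4, 2 percentage points apart, within the scatter of two such steps. With compound 2 at 0% and compound 4 at 2%, however, this agreement holds only among very small numbers at a single dose, and it does not show how the change would behave on a compound with a large read-out, nor does it say anything about potency.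

The compounds shown leave open whether a methoxy group, an amine or a carboxylic acid in place of chloro on that ring would read any differently in this assay. They also leave open what a longer chain on the sulfur of compound 3 would give.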